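A few compounds are considered here, and "the series" means these few. Any claim that something is new, unique, unknown or untested is made for them only; others in the source may bear on it.

In a toxicity assay on MRC5 cells (Homo sapiens) for inhibition, read by MTT assay, with a stated time of 72 h (a lower number here means a stronger inhibitor, a higher number a weaker inhibitor), compound 3 `CCCCCCCCCCC(=O)OCCc1ccc(O)c(O)c1` gives > 50000 nM, which is a limit and not a number. Compound 4 `CCCCCCCC(=O)OCCc1ccc(O)c(O)c1` has a shorter chain: hydrogen in place of propyl on a saturated chain carbon, seven bonds along the chain from a carbonyl carbon, with hydrogen in place of propyl on a saturated chain carbon, seven bonds along the chain from a carbonyl carbon. Within the data shown here, two measured steps bear on this change. Compound 2 `CCCCCCCCCCCCC(=O)OCCc1ccc(O)c(O)c1`, with the longest chain, gives 13200 nM, and shortening it produced an at least 3.7-fold higher number from compound 2 to compound 3 (0.57 log units; beyond the scatter). Compound 1 `CCCC(=O)OCCc1ccc(O)c(O)c1`, with the shortest chain, gives 71500 nM, while a step that the limit leaves unreadable from compound 1 to compound 3 has no readable size. Compound 4 falls in chain length between compound 1 and compound 3, so it is expected to stay in their weak range. The expected result is a step that the limit leaves unreadable from compound 3 to compound 4, with no clear change beyond the scatter. For compound 4 the estimated value is 60000 nM, with an expected range from 28000 nM to 120000 nM.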

Compound 4, half-maximal inhibitory concentration: 104000 nM
Estimate against measurement, compound 4: 1.7-fold (0.24 log units) below; the range from low to high includes it.
By their numbers in this assay, from the lowest: compound 2; then compounds 1 and 4 (each within the scatter of the next).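

In this assay, the result gives a real number for a mid-length chain: hydrogen in place of pentyl, seven bonds along the chain from a carbonyl carbon, produces a 7.9-fold higher number from compound 2 to compound 4 (0.90 log units; beyond the scatter) and so keeps compound 2 apart. Butyl in place of hydrogen, three bonds along the chain from a carbonyl carbon, gives only a 1.5-fold higher number from compound 1 to compound 4 (0.16 log units; within the scatter), so the chain change separates compound 1 and compound 4 by no more than the scatter. Compound 3 gives > 50000 nM, which is a limit and not a number, so its steps cannot be read: the limit of > 50000 nM in this assay, at which 1 of the 4 values shown sits.

Still open, on these data alone, is whether a longer chain than that of compound 2 would bring the number lower. Also open, as far as these compounds go, is what an amine or a carboxylic acid on the chain would do.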